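This account rests on a few compounds, and the source may have more. Where it says the series, first, only, none or still open, it means among the compounds named here.

In a functional assay with Alpha-1A adrenergic receptor (Homo sapiens) as the target, read by calcium flux (a higher number here means a larger maximal response, a lower number a smaller maximal response), two compounds have so far been measured. Compound 1 `c1cncc(-c2ccccc2OCC2=NCCN2)c1` gives 109%, and compound 2 `Cc1csc(-c2ccccc2OCC2=NCCN2)n1` gives 104%. Among the measured compounds shown here, the single step between them, a number 5 percentage points lower from compound 1 to compound 2 (within the scatter), exchanged 4-methyl-1,3-thiazol-2-yl for pyridin-3-yl on an aromatic carbon and stays within the scatter. On the numbers shown, compound 2 therefore stands alongside compound 1 with no separation beyond the scatter, and nothing else is known about it. Compound 3 `Cc1cc(-c2ccccc2OCC2=NCCN2)sn1` is not yet measured; it differs from compound 2 by 3-methyl-1,2-thiazol-5-yl in place of 4-methyl-1,3-thiazol-2-yl on an aromatic carbon, the two having the same atoms joined differently. For the measured compounds named here, only one measured step bears on this, and it concerned a different ring; since a number 5 percentage points lower from compound 1 to compound 2 (within the scatter) was small, no step beyond the scatter is expected here. Compound 3 is expected to sit close to compound 2, at an estimated no change at the digits printed from compound 2 to compound 3 (within the scatter). The estimate for compound 3 in this assay is 104%, expected to lie between 90% and 118%.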

Compound 3, largest response reached (reported as maximum), in percent of the reference or control that the assay uses: 75%
For compound 3 the middle estimate is 29 percentage points above the measured one; measured number below the stated range.
By their numbers in this assay, from the lowest: compound 3; then compounds 2 and 1 (each within the scatter of the next).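

In this assay, this aromatic carbon, ortho to a group of 7 heavy atoms, proves sensitive to how the same atoms are joined: 4-methyl-1,3-thiazol-2-yl and 3-methyl-1,2-thiazol-5-yl match in every count, yet the exchange gives a number 29 percentage points lower from compound 2 to compound 3 (beyond the scatter) in the maximal response. Measured against pyridin-3-yl, the new ring gives a number 34 percentage points lower from compound 1 to compound 3 (beyond the scatter) here, so the position does not tolerate every five-membered aromatic ring with 2 hetero atoms equally, which the earlier step within the scatter could not show. Nothing measured here bears on why the response falls.

The compounds shown leave open whether the fall follows the arrangement of the ring atoms or the place of the methyl group, as 1,2-thiazol-5-yl without its methyl, or with an ethyl group instead, could tell. They also leave open how an amine or a carboxylic acid on the ring would behave.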